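Reshuffling the methyl pattern on the urea aryl group

The compounds below may be only part of what the source reports. "The series", "measured", "known", "first", "only" and "open" are said of these compounds alone.

Three ureas on a shared core differ only in the aryl group carried by the amide-type nitrogen: compound 1 `CCCCCCCC/C=C\CCCCCCCCNC(=O)Nc1c(C)cc(C)cc1C`, compound 2 `CCCCCCCC/C=C\CCCCCCCCNC(=O)Nc1c(Cl)cc(Cl)cc1Cl` and compound 3 `CCCCCCCC/C=C\CCCCCCCCNC(=O)Nc1cc(C)ccc1C`. In an assay on microsomes from intestinal mucosa for inhibition of acyl-CoA:cholesterol acyltransferase (Oryctolagus cuniculus) (on this read-out higher numbers stand for weaker inhibition and lower numbers for stronger inhibition), compound 1 gives 2900 nM, compound 2 gives 1200 nM and compound 3 gives 4500 nM. For the measured compounds named here, the single step that exchanges methyls for chlorines is a 2.4-fold lower number from compound 1 to compound 2 (0.38 log units; beyond the scatter), and against compound 3 the same chlorinated aryl stands at a 3.8-fold higher number from compound 2 to compound 3 (0.57 log units; beyond the scatter). Going by the values given here, the only step that merely rearranges methyl groups, a 1.6-fold higher number from compound 1 to compound 3 (0.19 log units; within the scatter), stays within the scatter; on it compound 3 sits at the upper edge of the three numbers, yet separated from compound 1 by less than the scatter.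

Compound 4 `CCCCCCCC/C=C\CCCCCCCCNC(=O)Nc1ccccc1CC` is another such rearrangement: 2-ethylphenyl in place of 2,5-dimethylphenyl on an amide-type nitrogen, with no chlorine entering. Because the comparable step a 1.6-fold higher number from compound 1 to compound 3 (0.19 log units; within the scatter) stayed within the scatter, the step from compound 3 to compound 4 is expected to be a 1.1-fold higher number from compound 3 to compound 4 (0.05 log units; within the scatter), not beyond the scatter in either direction. Compound 4 is therefore estimated at 5000 nM, with a range from 2000 nM to 12000 nM.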

Compound 4, half-maximal inhibitory concentration: 980 nM
Estimate against measurement, compound 4: 5.1-fold (0.71 log units) above, and the stated range ends above it.
By their numbers in this assay, from the lowest: compounds 4 and 2 (each within the scatter of the next); then compounds 1 and 3 (each within the scatter of the next).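

In this assay, the change from 2,5-dimethylphenyl to 2-ethylphenyl, which keeps the same atoms joined differently, gives a 4.6-fold lower number from compound 3 to compound 4 (0.66 log units; beyond the scatter), so a rearrangement of carbon alone on this amide-type nitrogen can move the number beyond the scatter, which the earlier methyl rearrangement did not show. Compound 4 also carries no chlorine, yet the comparison with the chlorinated aryl gives a 1.2-fold lower number from compound 2 to compound 4 (0.09 log units; within the scatter), while the comparison with the trimethylated aryl gives a 3.0-fold lower number from compound 1 to compound 4 (0.47 log units; beyond the scatter). Nothing given here bears on why this rearrangement shifts the number.

As far as these compounds go, it remains open whether 2-methylphenyl or 2-propylphenyl on the same nitrogen would give a number like that of compound 4, and so whether the length of the chain counts. A 2-chlorophenyl group would show whether one chlorine can stand in for the ethyl group.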